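Replacing 1,2-Dihydroxyethyl with (2-Hydroxyethyl)carbamoyl

The source may report more compounds than this note shows. Statements on the series, on what has been measured and on what is new or still open speak of the compounds shown alone.

Measured so far:
compound 1 `C=CC[C@@H]1C[C@@H](c2ccc(Cl)c(Cl)c2)[C@H](NC(=O)c2cc(-c3c(Cl)cnn3C)c(Cl)o2)CN1`: 160 nM in a functional assay on LNCaP cells (Homo sapiens) for antiproliferative activity; a higher number here means a weaker inhibitor, a lower number a stronger inhibitor
compound 2 `Cn1ncc(Cl)c1-c1cc(C(=O)N[C@@H]2CN[C@H](CC(O)CO)C[C@H]2c2ccc(Cl)c(Cl)c2)oc1Cl`: 70 nM in this assay

Among the compounds with values here, compound 2 holds the lowest of the two numbers in this assay; compound 1 is its only neighbour, separated by a 2.3-fold lower number from compound 1 to compound 2 (0.36 log units; beyond the scatter). Compound 3 `Cn1ncc(Cl)c1-c1cc(C(=O)N[C@@H]2CN[C@H](CC(=O)NCCO)C[C@H]2c2ccc(Cl)c(Cl)c2)oc1Cl` differs from compound 2 by (2-hydroxyethyl)carbamoyl in place of 1,2-dihydroxyethyl on a saturated chain carbon bound to a saturated ring carbon. Within the data shown here, only that one measured step bears on this change, and it was modest; nothing measured compares the entering group with 1,2-dihydroxyethyl, so no step beyond the scatter is expected. Compound 3 is therefore estimated at 70 nM, between 30 nM and 170 nM. The expected step is no change at the digits printed from compound 2 to compound 3 (within the scatter).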

Compound 3, half-maximal inhibitory concentration: 40 nM
Estimate against measurement, compound 3: 1.8-fold (0.24 log units) above; low and high end bracket the measured number.
By their numbers in this assay, from the lowest: compounds 3 and 2 (each within the scatter of the next); then compound 1.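

In this assay the change to (2-hydroxyethyl)carbamoyl on a saturated chain carbon bound to a saturated ring carbon gives a 1.8-fold lower number from compound 2 to compound 3 (0.24 log units; within the scatter) and so shows that this place takes the amide-bearing chain as well as the diol. Measured against vinyl, the same group gives a 4.0-fold lower number from compound 1 to compound 3 (0.60 log units; beyond the scatter) and so joins 1,2-dihydroxyethyl on the same side of vinyl. No evidence is available to explain either step. The compounds shown leave open how a carboxylic acid or an amine would read at this place. They also leave open whether a methyl amide, with no terminal hydroxyl, would read like compound 3.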